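Removing a methoxy group from a cyano-pyrimidinone thiazole series

The source may hold more compounds than are shown below. What is called first, only, known or untested is meant among the compounds shown, and "the series" means these compounds.

Measured compounds:
compound 1 `COc1ccc(-c2nc(SCC(=O)c3sc(-c4ccccc4)nc3C)[nH]c(=O)c2C#N)cc1`: 1.08%
compound 2 `COc1ccc(-c2nc(C)c(C(=O)CSc3nc(-c4ccc(OC)cc4)c(C#N)c(=O)[nH]3)s2)cc1`: 11.5%
compound 3 `COc1ccc(-c2nc(SCC(=O)c3sc(-c4ccc(Cl)cc4)nc3C)[nH]c(=O)c2C#N)cc1`: 16.6%

In a functional assay on U-87MG ATCC cells for antiproliferative activity against U-87 MG (Homo sapiens), read by MTT assay, with a stated time of 48 h, tested at 100 uM (a lower number here means a stronger effect, a higher number a weaker effect of the compound at the concentration tested), compound 2 gives the second highest of the three numbers. Its nearest neighbour is compound 3, with a number 5.1 percentage points higher from compound 2 to compound 3 (within the scatter), and its furthest is compound 1, with a number 10.4 percentage points higher from compound 1 to compound 2 (beyond the scatter). Compound 4 `COc1ccc(-c2nc(C)c(C(=O)CSc3nc(-c4ccccc4)c(C#N)c(=O)[nH]3)s2)cc1` differs from compound 2 by hydrogen in place of methoxy on an aromatic carbon, on the ring bearing the nitrile-substituted core rather than the thiazole. Among the measured compounds shown here, the step that bears on it is the one from compound 1 to compound 2, where methoxy entered in place of hydrogen and gave a number 10.4 percentage points higher from compound 1 to compound 2 (beyond the scatter); no step on the same ring is available. Reversing that change elsewhere, a modest drop toward a stronger effect is expected, a number 6.5 percentage points lower from compound 2 to compound 4 (within the scatter). Compound 4 is therefore estimated at 5%, between 0% and 18%.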

Compound 4, a percentage reported as activity, at one concentration (the size of the read-out at that concentration, not a potency): 10.9%
Compound 4: middle estimate off by 5.9 percentage points, on the low side; the measured number falls inside the stated range.
By their numbers in this assay, from the lowest: compounds 1, 4, 2 and 3 (each within the scatter of the next, the first and the last beyond it).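

In this assay, going from 4-methoxyphenyl to phenyl on the ring carried by the nitrile-substituted core leaves the number unchanged within the scatter (a number 0.6 percentage points lower from compound 2 to compound 4 (within the scatter)). The methoxy at this position therefore makes no readable difference, unlike the methoxy on the ring carried by the thiazole (a number 10.4 percentage points higher from compound 1 to compound 2 (beyond the scatter)). No measurement among the data offers an explanation for this contrast.

As far as these compounds go, whether an amine or a carboxylic acid at this position would shift the number remains open, as does whether a longer alkoxy chain would.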